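The source may hold more compounds than are shown below. What is called first, only, known or untested is meant among the compounds shown, and "the series" means these compounds.

Compound 1 `COc1cc(N(C)CCN(C)C)c(NC(=O)/C=C\C(C)C)cc1Nc1nc(C)cc(-c2cn(C)c3ccccc23)n1` and compound 3 `COc1cc(N(C)CCN(C)C)c(NC(=O)/C=C\C(C)C)cc1Nc1ncc(C#N)c(-c2cn(C)c3ccc(F)cc23)n1` carry the same amide chain on different cores; the difference between the two cores is not broken down here. In a functional assay on NCI-H1975 cells (Homo sapiens) for antiproliferative activity, read by MTT assay, with a stated time of 72 h (a higher number here means a weaker inhibitor, a lower number a stronger inhibitor), compound 1 gives 1230 nM and compound 3 gives 1130 nM, two numbers within the scatter of each other. Compound 2 `CCC/C=C\C(=O)Nc1cc(Nc2nc(C)cc(-c3cn(C)c4ccccc34)n2)c(OC)cc1N(C)CCN(C)C` differs from compound 1 only by propyl in place of isopropyl on a double-bonded chain carbon bound to a double-bonded chain carbon, and in this assay compound 2 gives 254 nM, so the change produced a 4.8-fold lower number from compound 1 to compound 2 (0.69 log units; beyond the scatter). Compound 4 `CCC/C=C\C(=O)Nc1cc(Nc2ncc(C#N)c(-c3cn(C)c4ccc(F)cc34)n2)c(OC)cc1N(C)CCN(C)C` carries the same change on the core of compound 3, namely (propyl in place of isopropyl on a double-bonded chain carbon bound to a double-bonded chain carbon). Compound 4 is expected to follow that earlier step, giving a 3.8-fold lower number from compound 3 to compound 4 (0.58 log units; beyond the scatter). This rests on a single pair, so a somewhat smaller step than before is allowed for. Compound 4 is therefore estimated at 300 nM, with a likely range from 120 nM to 800 nM.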

Compound 4, half-maximal inhibitory concentration: 2420 nM
For compound 4 the middle estimate is 8.1-fold (0.91 log units) below the measured one; measured number above the stated range.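

In this assay, propyl in place of isopropyl gives a 2.1-fold higher number from compound 3 to compound 4 (0.33 log units; beyond the scatter), the opposite direction to the step seen on the core of compound 1. The same change therefore does not behave alike on these two cores: the same change on two cores in this assay, a 4.8-fold lower number (0.69 log units; beyond the scatter) from compound 1 to compound 2 and a 2.1-fold higher number (0.33 log units; beyond the scatter) from compound 3 to compound 4, 10-fold (1.02 log units) apart, beyond the scatter of two such steps. Among the compounds shown here, a step measured on one of these cores is thus a poor guide to the other, but with only two pairs and cores that differ in more than one place, the data cannot show which part of the core matters or why.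

On these data alone, it remains open how a longer chain such as pentyl or a ring such as cyclopropyl would behave in this same place on each core. Also open, as far as these compounds go, is whether the nitrile alone, without the fluorine, would produce the same reversal.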